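The compounds below may be only part of what the source reports. "The series", "measured", "known", "first", "only" and "open" are said of these compounds alone.

Compound 1 `COc1cc2c(cc1OC)C(CC(=O)O)CC2` gives 20.4% in a functional assay on the whole organism (strain Wistar) for inhibition, with Rattus norvegicus as the target, read by paw edema, with stated times of 60 min and 6 h, at a dose of 100 mg/kg by the oral route; a higher number here means more inhibition at the dose given (going by the name of the read-out), a lower number less inhibition. On the numbers shown it stands level with compound 3 `CCNC(=O)CC1CCc2cc(OC)c(OC)cc21`, which gives 20.4%, the two together the lowest of three numbers, while compound 2 `CNC(=O)CC1CCc2cc(OC)c(OC)cc21` gives 24.1%. The steps of a number 3.7 percentage points higher from compound 1 to compound 2 (within the scatter) and no change at the digits printed from compound 1 to compound 3 (within the scatter) both stay within the scatter, as does the step of a number 3.7 percentage points lower from compound 2 to compound 3 (within the scatter). Compound 4 `COc1cc2c(cc1OC)C(CC(=O)NC(C)C)CC2` differs from compound 1 by isopropylamino in place of hydroxy on a carbonyl carbon. The two measured amide-forming steps from compound 1 bear directly on this change, and both were small, so no step beyond the scatter is expected here. The step of a number 1.6 percentage points higher from compound 1 to compound 4 (within the scatter) is therefore estimated to be small. For compound 4 the expected value is 22%, with a range from 12% to 32%.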

Compound 4, a percentage reported as inhibition, in the whole organism at one dose (the size of the read-out at that dose, not a potency): 37%
The estimate for compound 4 lay 15 percentage points below the measured number, and the stated range ends below it.
By their numbers in this assay, from the lowest: compounds 1, 3 and 2 (each within the scatter of the next); then compound 4.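

In this assay, for the compounds shown here, isopropylamino is the first group on this carbonyl carbon to move the number beyond the scatter, with a number 16.6 percentage points higher from compound 1 to compound 4 (beyond the scatter) as the step from the acid. The amide alone therefore does not set the level; the group on the nitrogen does, since a number 16.6 percentage points higher from compound 3 to compound 4 (beyond the scatter) for one added methyl and a number 12.9 percentage points higher from compound 2 to compound 4 (beyond the scatter) for isopropyl in place of methyl, whereas methylamino and ethylamino stayed within the scatter of each other. Nothing available explains this gain. Still open, as far as these compounds go, is whether a straight propyl chain on the nitrogen would match isopropyl, or whether a tert-butyl group would go further.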